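This account rests on a few compounds, and the source may have more. Where it says the series, first, only, none or still open, it means among the compounds named here.

Compound 1 `O=C1Nc2ccccc2/C1=C/c1ccc(-c2cn(-c3ccccc3Cl)nn2)cc1` and compound 2 `O=C1Nc2ccccc2/C1=C/c1ccc(-c2cn(-c3cccc(Cl)c3)nn2)cc1` differ by 3-chlorophenyl in place of 2-chlorophenyl on an aromatic nitrogen. In a functional assay on MKN-45 cells (Homo sapiens) for inhibition, read by CCK-8 assay, with a stated time of 24 h (a lower number here means a stronger inhibitor, a higher number a weaker inhibitor), compound 1 gives only the limit > 20000 nM. Compound 2 also gives only the limit > 20000 nM in this assay. That leaves a step that the two limits leave unreadable from compound 1 to compound 2, both values standing at the limit of > 20000 nM in this assay, at which 2 of the 3 values shown sit. Among the measured compounds shown here, compound 3 `O=C1Nc2ccc(F)cc2/C1=C/c1ccc(-c2cn(-c3ccccc3Cl)nn2)cc1` differs from compound 1 by fluoro in place of hydrogen on an aromatic carbon; in this assay compound 3 gives 7540 nM, the only number among the three, making an at least 2.6-fold lower number from compound 1 to compound 3 (0.42 log units; beyond the scatter). Compound 4 `O=C1Nc2ccc(F)cc2/C1=C/c1ccc(-c2cn(-c3cccc(Cl)c3)nn2)cc1` differs from compound 3 by 3-chlorophenyl in place of 2-chlorophenyl on an aromatic nitrogen, the same change as between compound 1 and compound 2, now on the fluorinated core of compound 3. Since that earlier step is unreadable, the expected step from compound 3 to compound 4 is set near no change, a 1.6-fold higher number from compound 3 to compound 4 (0.20 log units; within the scatter). Compound 4 is therefore estimated at 12000 nM, between 4000 nM and 30000 nM.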

Compound 4, half-maximal inhibitory concentration: 14100 nM
Beside the measured number, compound 4's estimate is 1.2-fold (0.07 log units) below it, and the stated range covers the measured number.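

In this assay, 3-chlorophenyl in place of 2-chlorophenyl on the fluorinated core gives a 1.9-fold higher number from compound 3 to compound 4 (0.27 log units; within the scatter), and the same change cannot be read on the core of compound 1. Fluoro in place of hydrogen on an aromatic carbon gives an at least 1.4-fold lower number from compound 2 to compound 4 (0.15 log units; that floor lies within the scatter), so the number falls on both cores, but this shows only a shared direction and not a shared size: the same change on two cores in this assay, an at least 2.6-fold lower number (0.42 log units; beyond the scatter) from compound 1 to compound 3 and an at least 1.4-fold lower number (0.15 log units; that floor lies within the scatter) from compound 2 to compound 4; the limit leaves it open whether they differ. Any reading of the series stays narrow, with some of its values not being numbers: the limit of > 20000 nM in this assay, at which 2 of the 4 values shown sit.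

The compounds shown leave open how a methoxy group or a nitrile would read in the place of the fluoro. They also leave open how an amine would read in the place of the chlorine on the phenyl ring.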